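The source may hold more compounds than are shown below. What is called first, only, known or untested is meant among the compounds shown, and "the series" means these compounds.

Compound 3 `O=C(N[C@H]1CCC[C@H](NC(=O)c2ccccn2)C1)c1cccc(Cl)c1` and compound 2 `O=C(NC1CCCC(NC(=O)c2ccccn2)C1)c1cccc(Cl)c1` have the same atoms and bonds and differ only in whether the configuration of the two ring stereocentres is drawn. In a functional assay on HEK293 cells for antagonist activity at metabotropic glutamate receptor 5 (Homo sapiens), read by FLIPR and calcium flux (on this read-out higher numbers stand for weaker inhibition and lower numbers for stronger inhibition), compound 3 gives only a limit of the assay, > 10000 nM. Compound 2, drawn without a configuration, gives 314 nM in this assay. The step of an at least 31-fold higher number from compound 2 to compound 3 (1.50 log units; beyond the scatter) is large; it goes together with the fact that one of compounds 2 and 3 is drawn with a defined configuration and the other without, at the place where they differ. Compound 1 `N#Cc1cccc(C(=O)N[C@H]2CCC[C@H](NC(=O)c3ccccn3)C2)c1` carries a nitrile where compound 3 carries chloro. In this assay compound 1 also gives only a limit, > 10000 nM. The step that the two limits leave unreadable from compound 1 to compound 3 cannot be sized, due to the limit of > 10000 nM in this assay, at which 2 of the 3 values shown sit.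

Compound 4 `Cc1cccc(C(=O)N[C@H]2CCC[C@H](NC(=O)c3ccccn3)C2)c1` differs from compound 3 by methyl in place of chloro on an aromatic carbon. Within the data shown here, no measured step tests this exchange directly. What is known is that swapping the aromatic substituent between compound 1 and compound 3 gave no readable movement, while the large step came between compound 2 and compound 3, which share the chloro group. Compound 4 is therefore expected to stay at the limit as well, with a step that the limit leaves unreadable from compound 3 to compound 4 of essentially none beyond the scatter. The estimate for compound 4 is 15000 nM, with a range from 3000 nM to 60000 nM.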

Compound 4, half-maximal inhibitory concentration: 1000 nM
The estimate for compound 4 lay 15-fold (1.18 log units) above the measured number; the measured number lies below the stated range.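

With the shared core and its drawn configuration held fixed, the group on this aromatic carbon clearly matters in this assay: methyl in place of chloro gives an at least 10-fold lower number from compound 3 to compound 4 (1.00 log units; beyond the scatter), and methyl in place of nitrile gives an at least 10-fold lower number from compound 1 to compound 4 (1.00 log units; beyond the scatter). The earlier pair could not show this, since compound 1 and compound 3 both gave only a limit of the assay, whereas compound 4 gives a real number with the same drawn configuration. Both steps give only a minimum size, due to one thing: the limit of > 10000 nM in this assay, at which 2 of the 4 values shown sit.

On these data alone, it remains open whether an ethyl group, a methoxy group or an amine on this aromatic carbon would match or pass methyl. Also open, as far as these compounds go, is how the 3-methylphenyl compound would read with its two ring stereocentres drawn without a configuration or drawn the other way.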